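A few compounds are considered here, and "the series" means these few. Any claim that something is new, unique, unknown or untested is made for them only; others in the source may bear on it.

For the measured compounds named here, compound 2 `O=C(C1CCCCC1)N1CCc2nc(C#Cc3ccccc3)sc2C1` gives 167 nM in an assay on HEK293 cells for positive allosteric modulation of metabotropic glutamate receptor 5 (Homo sapiens), read by FLIPR, with a stated time of 1 h (on this read-out lower numbers stand for an effect already at smaller amounts and higher numbers for an effect only at larger amounts of compound), the lowest of the two numbers measured so far; compound 1 `O=C(C1CCCO1)N1CCc2nc(C#Cc3ccccc3)sc2C1` gives 790 nM in this assay. Going by the values given here, the one measured step, a 4.7-fold lower number from compound 1 to compound 2 (0.67 log units; beyond the scatter), exchanged a five-membered ring with one hetero atom for a carbon-only six-membered ring. Compound 3 `O=C(CC1CCOCC1)N1CCc2nc(C#Cc3ccccc3)sc2C1` differs from compound 2 by (oxan-4-yl)methyl in place of cyclohexyl on a carbonyl carbon, so a ring with one hetero atom returns. That earlier step bears on this one and suggests a shift back toward compound 1, though it is not the same exchange. The expected step is a 2.4-fold higher number from compound 2 to compound 3 (0.38 log units; beyond the scatter). Compound 3 is therefore estimated at 400 nM, with a range from 150 nM to 1200 nM.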

Compound 3, half-maximal effective concentration: 470 nM
For compound 3 the middle estimate is 1.2-fold (0.07 log units) below the measured one; measured number inside the range.
By their numbers in this assay, from the lowest: compound 2; then compounds 3 and 1 (each within the scatter of the next).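

With a 2.8-fold higher number from compound 2 to compound 3 (0.45 log units; beyond the scatter) as the step, a ring holding one oxygen on this carbonyl carbon again goes with a higher number than cyclohexyl, now as (oxan-4-yl)methyl rather than oxolan-2-yl. The two oxygen-bearing groups cannot be told apart here, since what separates them is a 1.7-fold lower number from compound 1 to compound 3 (0.23 log units; within the scatter) and that stays within the usual scatter. Nothing at hand gives a reason for either step.

Going by these compounds, it remains open whether the ring oxygen or the added linking carbon accounts for the step away from cyclohexyl, which cyclohexylmethyl would help to separate. On these data alone, how a ring nitrogen, as in a piperidine, would fare at this place also remains open.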